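The compounds below may be only part of what the source reports. "The series", "measured", "known", "first", "only" and "open" are said of these compounds alone.

Measured compounds:
Compound 1, `Cc1ccc(C2C(C#N)=C(N)N(c3ccc(S(N)(=O)=O)cc3)C3=C2CCCC3)cc1`: 20%
Compound 2, `N#CC1=C(N)N(c2ccc(S(N)(=O)=O)cc2)C2=C(CCCC2)C1c1c(O)ccc2ccccc12`: 10%

In a functional assay on Ehrlich cells (Mus musculus) for cytotoxicity, read by trypan blue exclusion, with a stated time of 2 h, tested at 10 ug/mL (on this read-out lower numbers stand for a weaker effect and higher numbers for a stronger effect at the one concentration tested), compound 2 gives 10%, while compound 1 gives 20%; the two numbers sit within the scatter of each other, so neither can be called the weaker. Compound 3, `N#CC1=C(N)N(c2ccc(S(N)(=O)=O)cc2)C2=C(CCCC2)C1c1cccs1`, differs from compound 2 by thiophen-2-yl in place of 2-hydroxynaphthalen-1-yl on a saturated ring carbon. Within the data shown here, the one measured step at this same saturated ring carbon, a number 10 percentage points lower from compound 1 to compound 2 (within the scatter), stayed within the scatter, so the step to compound 3 is expected to bring nothing beyond the scatter either: a number 5 percentage points higher from compound 2 to compound 3 (within the scatter). Compound 3 is therefore estimated at 15%, with a range from 5% to 30%.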

Compound 3, a percentage reported as activity, at one concentration (the size of the read-out at that concentration, not a potency): 0%
Compound 3: the middle estimate sits 15 percentage points above what was measured, and the stated range ends above it.
By their numbers in this assay, from the lowest: compounds 3, 2 and 1 (each within the scatter of the next, the first and the last beyond it).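

Thiophen-2-yl gives the first step at this saturated ring carbon that lies beyond the scatter, a number 20 percentage points lower from compound 1 to compound 3 (beyond the scatter) in this assay and modest in size. Measured against the 2-hydroxynaphthalen-1-yl group, the same entrant shows a number 10 percentage points lower from compound 2 to compound 3 (within the scatter) and cannot be told apart, so only the two ends of this short series separate. Nothing at hand explains the change. Still open, on these data alone, is whether a simple methyl group, or a phenyl ring bearing an amine or a carboxylic acid, on this carbon would lift the read-out past that of compound 1.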